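Changing the Side Chain of Compound 2

The source may report more compounds than this note shows. Statements on the series, on what has been measured and on what is new or still open speak of the compounds shown alone.

In a physicochemical assay for solubility, read by HPLC, using the shake flask method, in phosphate buffer, with a stated time of 20 h, at pH 6.5 (a higher number here means a more soluble compound, a lower number a less soluble compound), compound 1 (`CN1CCN(CC2CCN(c3nccc4[nH]c(-c5cccc(OC(F)(F)F)c5)nc34)CC2)CC1`) gives 200000 nM as its measured solubility. Compound 2 (`Fc1ccc(-c2nc3c(N4CCC(N5CCNCC5)CC4)nccc3[nH]2)cc1C(F)(F)F`) stands level with it, giving 200000 nM with no difference beyond the scatter. Compound 3 (`CN1CCN(CC2CCN(c3nccc4[nH]c(-c5ccc(F)c(C(F)(F)F)c5)nc34)CC2)CC1`) differs from compound 2 in one place ((4-methylpiperazin-1-yl)methyl in place of piperazin-1-yl on a saturated ring carbon), with (4-methylpiperazin-1-yl)methyl in place of piperazin-1-yl on a saturated ring carbon. The same (4-methylpiperazin-1-yl)methyl group is carried by compound 1, which gives 200000 nM in this assay and thus reads the same as compound 2 at the digits shown. Among the compounds with values here, no measured pair isolates this change, so any forecast remains an expectation resting on these two values. In this assay the expected step of no change at the digits printed from compound 2 to compound 3 (within the scatter) is none beyond the scatter, in neither direction. Compound 3 is expected to read 200000 nM with an estimated range from 100000 nM to 250000 nM once measured.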

Compound 3, solubility: 165000 nM
Beside the measured number, compound 3's estimate is 1.2-fold (0.08 log units) above it; the range from low to high includes it.
By their numbers in this assay, from the lowest: compounds 3, 1 and 2 (each within the scatter of the next).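

In this assay, within the data shown here, the step of a 1.2-fold lower number from compound 2 to compound 3 (0.08 log units; within the scatter) gives the first measured pair that isolates (4-methylpiperazin-1-yl)methyl in place of piperazin-1-yl on a saturated ring carbon, and the two compounds show no difference beyond the scatter. A second single change can now be read as well: 4-fluoro-3-(trifluoromethyl)phenyl in place of 3-(trifluoromethoxy)phenyl on an aromatic carbon gives a 1.2-fold lower number from compound 1 to compound 3 (0.08 log units; within the scatter) and likewise stays within the scatter. Nothing available here offers an explanation for either result.

Going by these compounds, both changes swap closely related groups, so it remains open whether a carboxylic acid or an open-chain amine such as dimethylamino on the saturated ring carbon would read differently in this assay. On these data alone, it is also open whether an aromatic carbon bearing a nitrile in place of the fluorinated groups would shift the number beyond the scatter.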